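The compounds below may be only part of what the source reports. "The series", "measured", "known", "first", "only" and "open" are said of these compounds alone.

Values in a functional assay on KG-1 cells (Homo sapiens) for cytotoxicity, read by luminescence and CellTiter-Glo, with a stated time of 3 days (a higher number here means a weaker inhibitor, a lower number a stronger inhibitor), for the compounds measured so far:
Compound 1 `O=C(Nc1ccc(C(F)(F)F)cc1)c1ccc(Cl)cc1O` gives 580 nM
Compound 2 `O=C(Nc1ccc(C(F)(F)F)cc1)c1ccc(Br)cc1O` gives 340 nM
Compound 3 `O=C(Nc1ccc(C(F)(F)F)cc1)c1ccc(F)cc1O` gives 740 nM

Compound 2 is the starting point here, and two steps set its place. They are a 1.7-fold lower number from compound 1 to compound 2 (0.23 log units; within the scatter) and a 2.2-fold higher number from compound 2 to compound 3 (0.34 log units; beyond the scatter), so it matches one neighbour and lies modestly under the other.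

Compound 4 `N#Cc1ccc(NC(=O)c2ccc(Br)cc2O)cc1` keeps the bromo group, and the change is cyano in place of trifluoromethyl on an aromatic carbon, which means cyano in place of trifluoromethyl on an aromatic carbon, para to a large group. Going by the values given here, none of the measured steps touches that place. All three swap one halogen for another, and even the largest, a 2.2-fold higher number from compound 2 to compound 3 (0.34 log units; beyond the scatter), is modest. They therefore offer only a rough size for a single swap and no direction. Trifluoromethyl is the only group measured at this place, so a modest rise in the number is a cautious guess. The estimated size of the change is a 1.9-fold higher number from compound 2 to compound 4 (0.28 log units; within the scatter), and its direction is the less certain part. For compound 4 the expected value is 650 nM, with an estimated range from 200 nM to 2200 nM.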

Compound 4, half-maximal inhibitory concentration: 1450 nM
Compound 4: middle estimate off by 2.2-fold (0.35 log units), on the low side, within the range that was stated.
By their numbers in this assay, from the lowest: compounds 2, 1, 3 and 4 (each within the scatter of the next, the first and the last beyond it).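

Cyano in place of trifluoromethyl gives a 4.3-fold higher number from compound 2 to compound 4 (0.63 log units; beyond the scatter) in this assay, so the place on the aromatic ring that holds these groups does affect the number, and for this pair the direction is now known. The halogen swaps could not show this, since they changed a different place and only a 2.2-fold higher number from compound 2 to compound 3 (0.34 log units; beyond the scatter) went beyond the scatter. No measurement shown here accounts for why this swap raises the number.

As far as these compounds go, with a single pair, it remains open whether trifluoromethyl is favoured over groups such as methyl, methoxy, an amine or a carboxylic acid at this place. From the compounds shown here alone, it is also open whether the same swap would have a similar effect in the compounds carrying chloro or fluoro in place of bromo.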